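The source may report more compounds than this note shows. Statements on the series, on what has been measured and on what is new or still open speak of the compounds shown alone.

Of the compounds shown here, three built on one shared core have been measured in a functional assay on HEK293 cells with D(4) dopamine receptor (Homo sapiens) as the target, read by FLIPR; a higher number here means that more compound is needed for the effect, a lower number that less compound is needed. Compound 1 `O/N=C(/CCN1CCN(c2ccccn2)CC1)c1ccccc1Cl` gives 25 nM, compound 3 `O/N=C(/CCN1CCN(c2ccccn2)CC1)c1cc(F)cc(F)c1` gives 17.5 nM, and compound 2 `Cc1ccccc1/C(CCN1CCN(c2ccccn2)CC1)=N/O` gives 4.2 nM. Compound 2 thus stands lowest of the three numbers; compound 3 is its nearest neighbour and compound 1 the furthest, and both gaps lie beyond the scatter. Going by the values given here, the single measured step between two compounds that differ in one place, a 1.4-fold lower number from compound 1 to compound 3 (0.15 log units; within the scatter), stays within the scatter.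

The unmeasured compound 4 `Cc1cc(C)cc(/C(CCN2CCN(c3ccccn3)CC2)=N/O)c1` differs from compound 2 as follows: 3,5-dimethylphenyl in place of 2-methylphenyl on a carbon with a double bond to nitrogen. Among the compounds with values here, only the step from compound 1 to compound 3 bears on this change, since there too a phenyl carrying one group on the carbon with the double bond to nitrogen was exchanged for a 3,5-difluorophenyl, just as a 3,5-dimethylphenyl enters here. That step produced no change beyond the scatter, so no step beyond the scatter is expected in this assay for compound 4 either. With compound 2 standing at the lowest number, 4.2 nM, the expectation leans toward a somewhat higher value for compound 4. Compound 4 is therefore estimated at 6 nM, within a range from 2.5 nM to 15 nM. This estimate corresponds to an expected step of a 1.4-fold higher number from compound 2 to compound 4 (0.15 log units; within the scatter).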

Compound 4, half-maximal effective concentration: 45.8 nM
Compound 4: the middle estimate sits 7.6-fold (0.88 log units) below what was measured; the whole stated range lies below it.
By their numbers in this assay, from the lowest: compound 2; then compounds 3, 1 and 4 (each within the scatter of the next, the first and the last beyond it).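

In this assay, the step of an 11-fold higher number from compound 2 to compound 4 (1.04 log units; beyond the scatter) shows that the group on the carbon with a double bond to nitrogen can matter a great deal, which the earlier step of a 1.4-fold lower number from compound 1 to compound 3 (0.15 log units; within the scatter), within the scatter, gave no sign of. Both steps bring in a 3,5-disubstituted phenyl by name, 3,5-difluorophenyl in one and 3,5-dimethylphenyl in the other, yet only the second moves the number beyond the scatter, so the earlier result does not carry over from one pair to the other. The leaving and entering groups here have the same ring, donor and acceptor counts and charge, and nothing available explains the size of this step.

The compounds shown leave open whether the rise comes from losing the 2-methylphenyl or from bringing in the 3,5-dimethylphenyl, as the step changes both at once. A plain phenyl on the same carbon would help separate the two, and ethyl groups in place of the methyl groups would show how far the result depends on the size of these substituents.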